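Trifluoromethyl added to the aromatic ring of compound 1

A few compounds are considered here, and "the series" means these few. Any claim that something is new, unique, unknown or untested is made for them only; others in the source may bear on it.

For the measured compounds named here, in a physicochemical assay for solubility, read by HPLC, in phosphate buffer, with a stated time of 24 h, at pH 7.4, tested at 100 uM (on this read-out higher numbers stand for higher solubility and lower numbers for lower solubility), compound 1 (`O=C(CCCCCNc1c(Nc2ccccc2)c(=O)c1=O)NO`) gives 47000000 nM and compound 2 (`O=C(CCCCNc1c(Nc2ccccc2)c(=O)c1=O)NO`) gives 87000000 nM as the only other measured value. The step of a 1.9-fold higher number from compound 1 to compound 2 (0.27 log units; within the scatter) leaves the two compounds within the scatter of each other and concerns the chain alone. Compound 3 (`O=C(CCCCCNc1c(Nc2ccc(C(F)(F)F)cc2)c(=O)c1=O)NO`) instead carries trifluoromethyl in place of hydrogen on an aromatic carbon. Going by the values given here, no measured step covers this change, so a moderate downward step in this assay is expected on the structural change alone. The expected step is a 3.9-fold lower number from compound 1 to compound 3 (0.59 log units; beyond the scatter) by this estimate. Compound 3 is expected at 12000000 nM with an estimated range of 3000000 nM to 40000000 nM in this measurement.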

Compound 3, solubility: 4500000 nM
Beside the measured number, compound 3's estimate is 2.7-fold (0.43 log units) above it; low and high end bracket the measured number.
By their numbers in this assay, from the lowest: compound 3; then compounds 1 and 2 (each within the scatter of the next).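

In this assay, trifluoromethyl in place of hydrogen on an aromatic carbon, para to a large group, gives a 10-fold lower number from compound 1 to compound 3 (1.02 log units; beyond the scatter), a large step. Among the compounds shown, this is the first step beyond the scatter, and it comes from the aromatic ring rather than the chain. Nothing shown accounts for the size of this step.

As far as these compounds go, whether it belongs to trifluoromethyl itself stays open; a fluorine, a methoxy group or an amine on that carbon would test this. From the compounds shown here alone, it also remains open whether the shorter chain of compound 2 would show the same step.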